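This account rests on a few compounds, and the source may have more. Where it says the series, first, only, none or still open, it means among the compounds named here.

Measured so far in a functional assay on the whole organism for inhibition, with Rattus norvegicus as the target, read by paw edema, with a stated time of 3 h, at a dose of 50 mg/kg; on this read-out higher numbers stand for more inhibition at the one dose given (going by the name of the read-out) and lower numbers for less inhibition:
compound 1 `CC(=O)c1c(NNc2ccc(Br)cc2)cc(C)oc1=O` gives 40.4%;
compound 2 `COc1ccc(NNc2cc(C)oc(=O)c2C(C)=O)cc1` gives 44.4%;
compound 3 `Cc1cc2nn(-c3ccc(Br)cc3)c(C)c2c(=O)o1` gives 49.5%.

Compound 1 and compound 2 differ in one place: methoxy in place of bromo on an aromatic carbon. This step is a number 4 percentage points higher from compound 1 to compound 2 (within the scatter). Compound 3 carries a different core from compound 1; the difference between the two cores is not broken down here. The value of compound 3 lies within the scatter of both compound 2 and compound 1, so no order among the three is claimed.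

Compound 4 `COc1ccc(-n2nc3cc(C)oc(=O)c3c2C)cc1` has not yet been measured in this assay. It differs from compound 3 by methoxy in place of bromo on an aromatic carbon, the same change, at the same place, as from compound 1 to compound 2. The step is expected to be a number 3.5 percentage points higher from compound 3 to compound 4 (within the scatter), comparable to a number 4 percentage points higher from compound 1 to compound 2 (within the scatter), because a number 4 percentage points higher from compound 1 to compound 2 (within the scatter) stayed within the scatter on the other core. Compound 4 is estimated at 53%, with a range from 40% to 66%.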

Compound 4, a percentage reported as inhibition, in the whole organism at one dose (the size of the read-out at that dose, not a potency): 57.6%
The estimate for compound 4 lay 4.6 percentage points below the measured number, within the range that was stated.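

In this assay methoxy in place of bromo on an aromatic carbon gives a number 8.1 percentage points higher from compound 3 to compound 4 (within the scatter) on the core of compound 3. Set beside the earlier step, the change carries from one core to the other with no difference that can be told apart: the same change on two cores in this assay, a number 4 percentage points higher (within the scatter) from compound 1 to compound 2 and a number 8.1 percentage points higher (within the scatter) from compound 3 to compound 4, 4.1 percentage points apart, within the scatter of two such steps. This shows agreement within the scatter for one change on two cores only; it does not show that methoxy raises the number on either core, since each step alone stays within the scatter.

Only bromo and methoxy are shown at this place on the aromatic ring. On these data alone, an amine, a carboxylic acid or a longer chain such as ethoxy there remains open on both cores.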